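The source may hold more compounds than are shown below. What is called first, only, known or untested is meant among the compounds shown, and "the series" means these compounds.

In an assay on HEK-293T cells for inhibition of diacylglycerol lipase-alpha (Homo sapiens), read by colorimetric assay (a lower number here means a stronger inhibitor, a higher number a weaker inhibitor), compound 3 `O=Cc1coc(C(=O)CCCCCCc2ccccc2)n1` gives 1510 nM. Among the two numbers measured so far this is the higher one. Compound 2 `CS(=O)(=O)c1coc(C(=O)CCCCCCc2ccccc2)n1` gives 389 nM, and the step between them is a 3.9-fold higher number from compound 2 to compound 3 (0.59 log units; beyond the scatter). Compound 1 `Cn1nnc(C(=O)CCCCCCc2ccccc2)n1` gives > 10000 nM, which is a limit of the assay and not a number. On these data alone, its step to compound 3 reads an at least 6.6-fold lower number from compound 1 to compound 3 (0.82 log units; beyond the scatter), and because the limit of > 10000 nM in this assay, at which 1 of the 3 values shown sits, the true size of that step stays open. Compound 4 `O=C(CCCCCCc1ccccc1)c1nc(Cl)co1` has not yet been measured. It differs from compound 3 by chloro in place of formyl on an aromatic carbon. Neither measured step covers this change: one exchanges the whole ring, the other puts formyl in place of methylsulfonyl. Both show that what sits on the ring matters, yet neither tells in which direction a chloro group moves the number. The expectation for compound 4 is therefore a step of a 1.7-fold higher number from compound 3 to compound 4 (0.22 log units; within the scatter), close to the scatter or a little weaker. Compound 4 is expected to give 2500 nM, with a range from 600 nM to 10000 nM.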

Compound 4, half-maximal inhibitory concentration: 2400 nM
For compound 4 the middle estimate is 1.0-fold (0.02 log units) above the measured one; low and high end bracket the measured number.
By their numbers in this assay, from the lowest: compound 2; then compounds 3 and 4 (each within the scatter of the next). At a limit, above all of these: compound 1.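

At this position, on an aromatic carbon next to the ring nitrogen, formyl and chloro cannot be told apart (see a 1.6-fold higher number from compound 3 to compound 4 (0.20 log units; within the scatter)), even though chloro has fewer heavy atoms and no hydrogen-bond acceptor. Of the three groups shown on this carbon, methylsulfonyl alone stands apart, and it does so against chloro as well as formyl (a 6.2-fold higher number from compound 2 to compound 4 (0.79 log units; beyond the scatter)). The exchange of the whole ring now reads an at least 4.1-fold lower number from compound 1 to compound 4 (0.61 log units; beyond the scatter), and the size of this step stays open at a limit of the assay: the limit of > 10000 nM in this assay, at which 1 of the 4 values shown sits.

The compounds shown hold only these three groups on this carbon, so they do not tell how an amine, a carboxylic acid or a methyl group there would move the number. They also leave open whether the gap between methylsulfonyl and chloro would hold with a longer chain on the carbonyl.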